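A few compounds are considered here, and "the series" means these few. Any claim that something is new, unique, unknown or untested is made for them only; others in the source may bear on it.

In an ADME assay on microsomes from liver (Mus musculus) for metabolic stability, read by LC-MS, using NADPH, with stated times of 6 min and 10 min, tested at 0.5 uM (a lower number here means that less of the compound is left, a higher number that more of the compound is left), compound 3 `CC(=O)N1C[C@@H](C)N(c2cc(-c3cc(C(F)(F)F)c4c(N)ncnn34)ccc2C#N)C(=O)C1(C)C` gives 23%, level with compound 1 `CC(=O)N1C[C@@H](C)N(c2cc(-c3cc(Cl)c4c(N)ncnn34)ccc2C#N)C(=O)C1(C)C` at 22% and far short of compound 2 `CC(=O)N1C[C@H](C)N(c2cc(-c3cc(Cl)c4c(N)ncnn34)ccc2C#N)C(=O)C1(C)C` at 85%. Compound 4 `CC(=O)N1C[C@H](C)N(c2cc(-c3cc(C(F)(F)F)c4c(N)ncnn34)ccc2C#N)C(=O)C1(C)C` departs from compound 3 in a single way: the two compounds have the same atoms and bonds and differ only in configuration as drawn: 1 of 1 stereo elements differ; a stereocentre at a saturated ring carbon is drawn R in compound 3 and S in compound 4. For the measured compounds named here, only one measured step involves this kind of change: a number 63 percentage points higher from compound 1 to compound 2 (beyond the scatter). That step is large, and because of the fact that compounds 1 and 2 differ only in the configuration as drawn it can rest on configuration alone. Trifluoromethyl in place of chloro gave only a number 1 percentage points higher from compound 1 to compound 3 (within the scatter), so compound 3 offers the same starting point as compound 1. A rise of similar size to that seen for compound 2 is therefore expected in this assay, an estimated a number 59 percentage points higher from compound 3 to compound 4 (beyond the scatter). Compound 4 is expected at 82%, within an estimated range of 65% to 94%.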

Compound 4, percent of the compound remaining: 100%
Compound 4: middle estimate off by 18 percentage points, on the low side; the measured number lies above the stated range.
By their numbers in this assay, from the lowest: compounds 1 and 3 (each within the scatter of the next); then compound 2; then compound 4.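

In this assay, the drawn configuration at this saturated ring carbon matters on a second core, with a number 77 percentage points higher from compound 3 to compound 4 (beyond the scatter), so the large rise no longer rests on one pair of compounds: the fact that compounds 3 and 4 differ only in the configuration as drawn. Trifluoromethyl in place of chloro gives a number 15 percentage points higher from compound 2 to compound 4 (beyond the scatter) among the S compounds, yet this step cannot be told apart from its counterpart among the R compounds: the same change on two cores in this assay, a number 1 percentage points higher (within the scatter) from compound 1 to compound 3 and a number 15 percentage points higher (beyond the scatter) from compound 2 to compound 4, 14 percentage points apart, within the scatter of two such steps.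

Still open, going by these compounds, is whether S stays ahead of R with an ethyl group in place of the methyl at this stereocentre. Also open, on these data alone, is how bromo or methoxy would compare with chloro and trifluoromethyl on the aromatic carbon.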